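Shortening the Linker Between Phenoxy and Tetrahydroisoquinoline

The source may hold more compounds than are shown below. What is called first, only, known or untested is meant among the compounds shown, and "the series" means these compounds.

Two compounds set the scene. Compound 1, `O=C(/C=C/c1cccc(OCCCCCCN2CCc3ccccc3C2)c1)c1ccccc1O`, carries a long saturated chain joining the aromatic oxygen to the tetrahydroisoquinoline nitrogen. In an assay on cells for inhibition of Amine oxidase [flavin-containing] B (Homo sapiens), read by fluorescence, with a stated time of 30 min (on this read-out lower numbers stand for stronger inhibition and higher numbers for weaker inhibition), compound 1 gives 6700 nM. Compound 2, `O=C(/C=C/c1cccc(OCCCN2CCc3ccccc3C2)c1)c1ccccc1O`, has a shorter chain in the same place and gives 10700 nM in this assay. Compound 1 shows the lower of the two numbers, yet the gap to compound 2 lies within the scatter of repeated measurements, so the two values cannot be told apart with confidence.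

Compound 3, `O=C(/C=C/c1cccc(OCCCCCN2CCc3ccccc3C2)c1)c1ccccc1O`, sits between them in chain length. Compared with compound 1 the change is 1,2,3,4-tetrahydroisoquinolin-2-yl in place of (1,2,3,4-tetrahydroisoquinolin-2-yl)methyl on a saturated chain carbon, five bonds along the chain from an oxygen on an aromatic ring. Among the compounds with values here, neither measured pair was shortened in just this way, so no measured step is available for direct comparison. Compound 1 gave 6700 nM and compound 2 gave 10700 nM, without a difference beyond the scatter. The step from compound 1 to compound 3 is therefore expected to be small, a 1.2-fold higher number from compound 1 to compound 3 (0.08 log units; within the scatter), with no clear direction. Compound 3 is therefore estimated at 8000 nM, within a range of 3500 nM to 18000 nM.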

Compound 3, half-maximal inhibitory concentration: 4800 nM
Compound 3: the middle estimate sits 1.7-fold (0.22 log units) above what was measured; the measured number falls inside the stated range.
By their numbers in this assay, from the lowest: compounds 3, 1 and 2 (each within the scatter of the next, the first and the last beyond it).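

In this assay, taking (1,2,3,4-tetrahydroisoquinolin-2-yl)methyl out and putting 1,2,3,4-tetrahydroisoquinolin-2-yl in its place gives a 1.4-fold lower number from compound 1 to compound 3 (0.14 log units; within the scatter) on a saturated chain carbon, five bonds along the chain from an oxygen on an aromatic ring, so this small trim of the chain cannot be told apart from repeat-measurement noise. Compound 3 does provide the first separation in the set: compound 2 (10700 nM) and compound 3 (4800 nM) lie beyond the scatter of each other, while compound 1 (6700 nM) lies within the scatter of both, and these three values do not follow chain length in a steady line. Nothing measured here explains these numbers.

From the compounds shown here alone, whether a longer chain, or an amide set into the chain in place of saturated carbons, would move the number clearly beyond the scatter of compound 3 stays open. Going by these compounds, it is equally open whether a piperidine in place of the tetrahydroisoquinoline would keep the values of this small series or shift them.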